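Working notes: dichlorophenyl swap across a small cytotoxicity series

This account rests on a few compounds, and the source may have more. Where it says the series, first, only, none or still open, it means among the compounds named here.

Measured so far in a functional assay on HeLa cells (Homo sapiens) for cytotoxicity, read by MTT assay, with a stated time of 24 h; on this read-out higher numbers stand for weaker inhibition and lower numbers for stronger inhibition:
compound 1 `CN1C/C(=C\c2ccc(Br)cc2)C(=O)/C(=C/c2cccc([N+](=O)[O-])c2)C1` gives 11900 nM
compound 2 `CN1C/C(=C\c2cccc([N+](=O)[O-])c2)C(=O)/C(=C/c2ccc(Cl)cc2Cl)C1` gives 8900 nM
compound 3 `CN1C/C(=C\c2ccc(Br)cc2)C(=O)/C(=C/c2ccc(C#N)cc2)C1` gives 5900 nM

Compound 4 `CN1C/C(=C\c2ccc(C#N)cc2)C(=O)/C(=C/c2ccc(Cl)cc2Cl)C1` is not yet measured in this assay. The change from compound 1 to compound 2 is 2,4-dichlorophenyl in place of 4-bromophenyl on a double-bonded chain carbon bound to a double-bonded ring carbon and produced a 1.3-fold lower number from compound 1 to compound 2 (0.13 log units; within the scatter). Compound 3 and compound 1 differ in more than the swapped group; the difference between the two cores is not broken down here. Compound 4 repeats the same change on compound 3, (2,4-dichlorophenyl in place of 4-bromophenyl on a double-bonded chain carbon bound to a double-bonded ring carbon), the place being identical in both pairs. Within the data shown here, since the earlier step was small, a step of about a 1.3-fold lower number from compound 3 to compound 4 (0.11 log units; within the scatter) is expected for compound 4, resting only on the single paired example and on compound 3 showing 5900 nM. On that basis compound 4 is estimated to give 4600 nM, with a plausible range of 2000 nM to 11000 nM.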

Compound 4, half-maximal inhibitory concentration: 7760 nM
The estimate for compound 4 lay 1.7-fold (0.23 log units) below the measured number; the measured number falls inside the stated range.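

In this assay, 2,4-dichlorophenyl in place of 4-bromophenyl gives a 1.3-fold higher number from compound 3 to compound 4 (0.12 log units; within the scatter), and the two instances of this change do not differ: the same change on two cores in this assay, a 1.3-fold lower number (0.13 log units; within the scatter) from compound 1 to compound 2 and a 1.3-fold higher number (0.12 log units; within the scatter) from compound 3 to compound 4, 1.8-fold (0.25 log units) apart, within the scatter of two such steps. On these two cores the change therefore carries over as a small step, but neither step can be told from scatter, so neither a direction nor a size for the change is established, and two cores say nothing about the rest of the series. The other new step, 4-cyanophenyl in place of 3-nitrophenyl, is also small: a 1.1-fold lower number from compound 2 to compound 4 (0.06 log units; within the scatter).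

Open, going by these compounds, is whether the swap stays this small on a core carrying an amine or a carboxylic acid on the other aryl group. Also open, on these data alone, is how a phenyl bearing a longer chain would compare at this place.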